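Methyl branch on compound 2: tolerability outlook

The compounds below may be only part of what the source reports. "The series", "measured", "known", "first", "only" and "open" are said of these compounds alone.

Compound 1 `Nc1ccc(CN2N=C(c3ccc(F)cc3)C3C=CC=CC3C2=O)cc1`, compound 2 `CN(C)CCCCN(C(=O)O)c1ccc(Cn2nc(-c3ccc(F)cc3)c3ccccc3c2=O)cc1` and compound 3 `CN(C)CCCCN(C(=O)O)c1ccccc1Cn1nc(-c2ccc(F)cc2)c2ccccc2c1=O` share one core and have been run in an ADME assay on Huh-7 cells (Homo sapiens) for cytotoxicity, read by MTT assay, with a stated time of 48 h; a lower number here means that less compound is tolerated, a higher number that more compound is tolerated. Compound 1 reaches only the limit of > 80000 nM, so for it no number is known; this is the limit of > 80000 nM in this assay, at which 1 of the 3 values shown sits. Compound 2 gives 19000 nM. Compound 3 gives 48500 nM. Of the two numbers, compound 2 holds the lower one, and the gap up to compound 3 lies beyond the scatter. For the measured compounds named here, no step between measured compounds differing in a single place has been recorded, so no measured change can be called on here.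

Compound 4 `CC(c1ccc(N(CCCCN(C)C)C(=O)O)cc1)n1nc(-c2ccc(F)cc2)c2ccccc2c1=O` differs from compound 2 by methyl in place of hydrogen on a saturated chain carbon bound to an aromatic carbon and an aromatic nitrogen. Compound 2 remains the nearest anchor with 19000 nM. In this assay the expected step is a 1.1-fold higher number from compound 2 to compound 4 (0.02 log units; within the scatter), none beyond the scatter. Compound 4 is accordingly estimated at 20000 nM, within 9000 nM to 45000 nM.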

Compound 4, half-maximal cytotoxic concentration: 15200 nM
Compound 4: the middle estimate sits 1.3-fold (0.12 log units) above what was measured, within the range that was stated.
By their numbers in this assay, from the lowest: compounds 4 and 2 (each within the scatter of the next); then compound 3. At a limit, above all of these: compound 1.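

In this assay, the saturated chain carbon bound to an aromatic carbon and an aromatic nitrogen now has its first measured single-place step, a 1.3-fold lower number from compound 2 to compound 4 (0.10 log units; within the scatter), for methyl in place of hydrogen. For the compounds shown here, this position therefore accepts one methyl with the number staying within the scatter, something the earlier compounds could not show, as no pair among them differed in a single place. No measured property shown here bears on this result.

From the compounds shown here alone, whether a larger group on this carbon, such as ethyl or a phenyl ring, or a hydroxyl in place of the methyl, would stay within the scatter remains open. Going by these compounds, it is equally open whether the same methyl on compound 3 would give a step of similar size.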